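Removing one acetoxy group from compound 2

The source may report more compounds than this note shows. Statements on the series, on what has been measured and on what is new or still open speak of the compounds shown alone.

Compound 1 `COC(=O)c1c(-c2ccc(Br)cc2)oc2ccccc2c1=O`: > 25 ug/mL (a limit)
Compound 2 `CC(=O)Nc1ccc(-c2cc(=O)c3c(OC(C)=O)cc(OC(C)=O)cc3o2)cc1`: 17.4 ug/mL

Both compounds were tested in a functional assay on HT-29 cells (Homo sapiens) for cytotoxicity, read by MTT assay, with a stated time of 6 days; on this read-out higher numbers stand for an effect only at larger amounts of compound and lower numbers for an effect already at smaller amounts. For the measured compounds named here, compound 2 gives 17.4 ug/mL, the only actual number so far. Compound 1 stands at a limit of the assay, > 25 ug/mL.

The next compound, compound 3 `CC(=O)Nc1ccc(-c2cc(=O)c3ccc(OC(C)=O)cc3o2)cc1`, has hydrogen in place of acetoxy on an aromatic carbon of compound 2: hydrogen in place of acetoxy on an aromatic carbon. Going by the values given here, no measured pair of compounds differs in a single place, so the data give no direct guide to the size of such a change in this assay. With no direction supported, no shift beyond the usual scatter is expected, although a result at the limit remains possible. The estimated 1.0-fold higher number from compound 2 to compound 3 (0.01 log units; within the scatter) is therefore small. For compound 3 the expected value is 18 ug/mL, with an estimated range from 8 ug/mL to 40 ug/mL.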

Compound 3, concentration for half-maximal effect: 19.8 ug/mL
Compound 3: middle estimate off by 1.1-fold (0.04 log units), on the low side, and the stated range covers the measured number.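

For the compounds shown here, this pair is the first that differs in a single place, and in this assay it gives a 1.1-fold higher number from compound 2 to compound 3 (0.06 log units; within the scatter). At this position, on the six-membered aromatic ring of carbon only and meta to the remaining acetoxy group, hydrogen can therefore stand in place of acetoxy, with its 4 heavy atoms, without a shift beyond the usual scatter. Compound 1 is a limit of the assay and takes no part in this reading: the limit of > 25 ug/mL in this assay, at which 1 of the 3 values shown sits.

From the compounds shown here alone, it remains open whether a hydroxyl group, a methoxy group or an amine at this position would read like hydrogen, and whether the remaining acetoxy group can be replaced in the same way. This single step also cannot say whether the same change would read alike in any other compound.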